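The source may hold more compounds than are shown below. What is called first, only, known or untested is meant among the compounds shown, and "the series" means these compounds.

Compound 1 `COc1ncc(-c2ccc3c(c2)N(c2ccc(C)cc2)C(=O)CO3)cc1NS(=O)(=O)c1ccc(F)cc1`: in a functional assay on HepG2 cells (Homo sapiens) for antiproliferative activity, read by MTT assay, with a stated time of 72 h (on this read-out higher numbers stand for weaker inhibition and lower numbers for stronger inhibition), compound 1 gives 28300 nM.
Compound 2 `COc1cccc(N2C(=O)COc3ccc(-c4cnc(Cl)c(NS(=O)(=O)c5ccc(F)cc5)c4)cc32)c1`: compound 2 reaches only a limit of the assay, > 40000 nM.

Within the data shown here, compound 1 stands as the only actual number among the two measured compounds, and it is a weak one. Compound 2 sits at the limit of > 40000 nM in this assay, at which 1 of the 2 values shown sits, which is a limit rather than a number. Compound 3 `COc1ccc(N2C(=O)COc3ccc(-c4cnc(OC)c(NS(=O)(=O)c5ccc(F)cc5)c4)cc32)cc1` has not yet been measured. It differs from compound 1 by methoxy in place of methyl on an aromatic carbon. Among the measured compounds shown here, no step between measured compounds is available to lean on, so the step of a 1.1-fold higher number from compound 1 to compound 3 (0.03 log units; within the scatter) is expected to stay within the usual scatter, in no clear direction. Compound 3 is estimated at 30000 nM, between 12000 nM and 60000 nM.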

Compound 3, half-maximal inhibitory concentration: 13100 nM
For compound 3 the middle estimate is 2.3-fold (0.36 log units) above the measured one, and the stated range covers the measured number.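

Among these compounds, replacing 4-methylphenyl with 4-methoxyphenyl gives a 2.2-fold lower number from compound 1 to compound 3 (0.33 log units; beyond the scatter) in this assay, the first step that can be read between two measured compounds differing in one place. The step is modest but beyond the scatter, so this position on the ring does respond to a change, although compound 3 still needs 13100 nM and remains weak. Nothing shown explains the direction of this step. On these data alone, whether an amine, a carboxylic acid or a longer chain at this same place would lower the number further remains open.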